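Side Chain Change on the Allyl Compound

A few compounds are considered here, and "the series" means these few. Any claim that something is new, unique, unknown or untested is made for them only; others in the source may bear on it.

Values in a functional assay on A-375 cells (Homo sapiens) for cytotoxicity, read by MTT assay, with a stated time of 72 h (on this read-out higher numbers stand for weaker inhibition and lower numbers for stronger inhibition), stand as follows.

- Compound 1 `COc1ccc(-c2cc3ccc(OC)c(OC)c3c(=O)[nH]2)cc1OC` gives > 10000 nM as a limit
- Compound 2 `C=CCn1c(-c2ccc(OC)c(OC)c2)cc2ccc(OC)c(OC)c2c1=O` gives 500 nM as a number
- Compound 3 `C=CCOc1nc(-c2ccc(OC)c(OC)c2)cc2ccc(OC)c(OC)c12` gives > 10000 nM as a limit
- Compound 4 `COc1ccc(-c2cc3ccc(OC)c(OC)c3c(=O)n2CCC=O)cc1OC` is still unmeasured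

Among the measured compounds shown here, compound 2 holds the only number in this assay and the other two values are limits. Compound 4 differs from it by formylmethyl in place of vinyl on a saturated chain carbon bound to an aromatic nitrogen. For the measured compounds named here, the one measured step bearing on this is an at least 20-fold lower number from compound 1 to compound 2 (1.30 log units; beyond the scatter), a large one, and it adds the chain rather than altering it. Compound 4 keeps a chain there, so the expected result is a 1.4-fold higher number from compound 2 to compound 4 (0.15 log units; within the scatter), with no change beyond the scatter. Compound 4 is estimated at 700 nM, within a range of 120 nM to 5000 nM.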

Compound 4, half-maximal inhibitory concentration: 5820 nM
For compound 4 the middle estimate is 8.3-fold (0.92 log units) below the measured one; measured number above the stated range.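

In this assay, the result shows that keeping a chain on the aromatic nitrogen does not by itself hold the number of compound 2, since formylmethyl in place of vinyl gives a 12-fold higher number from compound 2 to compound 4 (1.07 log units; beyond the scatter). With 2-formylethyl in place of hydrogen on the aromatic nitrogen, the change is an at least 1.7-fold lower number from compound 1 to compound 4 (0.23 log units; that floor lies within the scatter), so no gain from this chain can be told from the scatter. This step is only a floor because compound 1 stands at a limit: the limit of > 10000 nM in this assay, at which 2 of the 4 values shown sit.

Going by these compounds, whether an amine or a carboxylic acid in place of formylmethyl, or a longer chain, would keep the number of compound 2 remains open.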